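The source may hold more compounds than are shown below. What is called first, only, known or untested is meant among the compounds shown, and "the series" means these compounds.

Compounds measured in a functional assay on HeLa cells (Homo sapiens) for cytotoxicity, read by WST assay, with a stated time of 48 h; on this read-out higher numbers stand for weaker inhibition and lower numbers for stronger inhibition:
- compound 1 `COc1cc(C(c2ccc(O)c(OC)c2)[C@@H](C)[C@@H](C)CO)ccc1O`: > 100000 nM
- compound 2 `COc1cc(C(c2ccc(O)c(OC)c2)[C@@H](C)C(C)C)ccc1O`: 19000 nM
- compound 3 `COC[C@H](C)[C@@H](C)C(c1ccc(O)c(OC)c1)c1ccc(O)c(OC)c1`: 77000 nM

Compound 2 holds the lowest of the two numbers, with a 4.1-fold higher number from compound 2 to compound 3 (0.61 log units; beyond the scatter) to its nearest neighbour. For compound 1 the value is a limit of the assay (the limit of > 100000 nM in this assay, at which 1 of the 3 values shown sits). Removal of the chain hydroxy gave an at least 5.2-fold lower number from compound 1 to compound 2 (0.72 log units; beyond the scatter). Compound 4 `COc1cc(C(c2ccc(O)c(OC)c2)[C@H](CO)C(C)C)ccc1O` differs from compound 2 by 1-(hydroxymethyl)-2-methylpropyl in place of 1,2-dimethylpropyl on a saturated chain carbon bound to two aromatic carbons. Both steps bear on this change: the hydroxy removal that gave an at least 5.2-fold lower number from compound 1 to compound 2 (0.72 log units; beyond the scatter) and the methoxymethyl entry that gave a 4.1-fold higher number from compound 2 to compound 3 (0.61 log units; beyond the scatter) each point to a higher number when oxygen returns to the chain. Compound 4 is therefore expected to give 60000 nM in this assay, within 20000 nM to 200000 nM. The expected step is a 3.2-fold higher number from compound 2 to compound 4 (0.50 log units; beyond the scatter).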

Compound 4, half-maximal inhibitory concentration: > 100000 nM
Compound 4: a limit, no number; the forecaster's own chance of this, stated with the estimate: 35%; middle value at least 1.6-fold (0.22 log units) away from the limit.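

The 1-(hydroxymethyl)-2-methylpropyl group in place of 1,2-dimethylpropyl gave an at least 5.2-fold higher number from compound 2 to compound 4 (0.72 log units; beyond the scatter), so in this assay a chain hydroxy raised the number in this branching too, not only in that of compound 1. Against the 2-(methoxymethyl)-1-methylpropyl group it gave an at least 1.2-fold higher number from compound 3 to compound 4 (0.11 log units; that floor lies within the scatter), which sets no order between the two. The step between compound 1 and compound 4 cannot be read, as each value is a limit: the limit of > 100000 nM in this assay, at which 2 of the 4 values shown sit.

The compounds shown leave open whether an amine or a carboxylic acid on this chain would also raise the number, and whether a longer chain without oxygen would lower it.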